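The source may hold more compounds than are shown below. What is called first, only, known or untested is meant among the compounds shown, and "the series" means these compounds.

Of the compounds shown here, three sharing one core have been tested in a functional assay on cells for antagonist activity at prostaglandin D2 receptor 2 (Homo sapiens), read by flow cytometry, with a stated time of 10 min; on this read-out lower numbers stand for stronger inhibition and higher numbers for weaker inhibition. Compound 1, `COCCN(C)S(=O)(=O)c1ccc(C)c(C#Cc2cc(Cl)ccc2OCC(=O)O)c1`, gives 77 nM. Compound 2, `CC(C)c1ccc(S(C)(=O)=O)cc1C#Cc1cc(Cl)ccc1OCC(=O)O`, gives 360 nM. Compound 3, `Cc1ccc(S(=O)(=O)N(C)C)cc1C#Cc1cc(Cl)ccc1OCC(=O)O`, gives 77 nM. Compound 3 thus stands level with compound 1 at the lowest numbers of the three, while compound 2 gives a higher number, a gap that lies beyond the usual scatter. Among the compounds with values here, the one single-point step available, no change at the digits printed from compound 1 to compound 3 (within the scatter), shows that trimming the sulfonamide nitrogen leaves the read-out unchanged.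

Compound 4, `Cc1ccc(S(C)(=O)=O)cc1C#Cc1cc(Cl)ccc1OCC(=O)O`, differs from compound 3 by methyl in place of dimethylamino on a sulfonyl sulfur. Within the data shown here, no measured step addresses this position directly. Compound 2 carries the methylsulfonyl group but also differs from compound 3 elsewhere, so its higher number cannot be laid at the door of the sulfonyl change alone, and the step from compound 1 to compound 3 touches a different site. The expectation for compound 4 is therefore uncertain, leaning toward a somewhat higher number, estimated as a 1.9-fold higher number from compound 3 to compound 4 (0.29 log units; within the scatter). Compound 4 is expected to give about 150 nM in this assay, with a likely range from 50 nM to 500 nM.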

Compound 4, half-maximal inhibitory concentration: 64 nM
For compound 4 the middle estimate is 2.3-fold (0.37 log units) above the measured one; the range from low to high includes it.
By their numbers in this assay, from the lowest: compounds 4, 1 and 3 (each within the scatter of the next); then compound 2.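

In this assay, the change on the sulfonyl sulfur can now be read directly: putting methyl in place of dimethylamino gives a 1.2-fold lower number from compound 3 to compound 4 (0.08 log units; within the scatter), and putting methyl in place of the larger (2-methoxyethyl)(methyl)amino gives a 1.2-fold lower number from compound 1 to compound 4 (0.08 log units; within the scatter), so neither replacement moves the read-out beyond the usual scatter of repeated measurements. The methylsulfonyl group therefore matches both sulfonamides here, and what sits on this sulfur, among the three groups seen so far, makes no measurable difference. With methyl in place of isopropyl on an aromatic carbon, there is a 5.6-fold lower number from compound 2 to compound 4 (0.75 log units; beyond the scatter), which places the weaker read-out of compound 2 with the isopropyl group rather than with its methylsulfonyl group, although nothing available explains either result.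

The compounds shown leave open whether a free amino group or a morpholine on the sulfonyl sulfur would also stay level with these three groups. They also leave open how an ethyl or cyclopropyl group would read on that aromatic carbon, where only methyl and isopropyl appear, and so whether the rise seen with isopropyl comes on gradually or abruptly.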